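Swapping chloro for methoxycarbonyl on the benzimidazole acetic acid series

The source may hold more compounds than are shown below. What is called first, only, known or untested is meant among the compounds shown, and "the series" means these compounds.

Of the compounds shown here, three sharing one core have been measured in an assay on HEK293 cells for displacement of a labelled ligand from prostaglandin D2 receptor 2 (Homo sapiens); a higher number here means a weaker inhibitor, a lower number a stronger inhibitor. Compound 1 `COC(=O)c1cccc(CSc2nc3ccccc3n2CC(=O)O)c1` gives 450 nM, compound 2 `COc1ccc(C)cc1CSc1nc2ccccc2n1CC(=O)O` gives 1200 nM, and compound 3 `COc1ccc(Cl)cc1CSc1nc2ccccc2n1CC(=O)O` gives 740 nM. Compound 3 thus sits second highest of the three numbers, though each of its gaps to the others is within the scatter. Among the compounds with values here, the one single-point step seen so far, a 1.6-fold lower number from compound 2 to compound 3 (0.21 log units; within the scatter), changed nothing beyond that scatter.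

Compound 4 `COC(=O)c1ccc(OC)c(CSc2nc3ccccc3n2CC(=O)O)c1` arises from compound 3 by the change (methoxycarbonyl in place of chloro on an aromatic carbon). Within the data shown here, no measured step covers this exact exchange. Compound 1 already carries a methoxycarbonyl group, but it also lacks the methoxy group of compound 3, so the two differ in two places; their values simply show that a methoxycarbonyl-bearing compound can reach the lower end of this small set. On that slender basis, the expected step of a 1.5-fold lower number from compound 3 to compound 4 (0.17 log units; within the scatter) is small, pointing slightly toward a lower number. Compound 4 is therefore estimated at 500 nM, with a plausible range from 200 nM to 1500 nM.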

Compound 4, half-maximal inhibitory concentration: 29 nM
Estimate against measurement, compound 4: 17-fold (1.24 log units) above; measured number outside the range, below it.
By their numbers in this assay, from the lowest: compound 4; then compounds 1, 3 and 2 (each within the scatter of the next, the first and the last beyond it).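

In this assay, methoxycarbonyl in place of chloro on the aromatic carbon para to a methoxy group brings a 26-fold lower number from compound 3 to compound 4 (1.41 log units; beyond the scatter), and in place of methyl it brings a 41-fold lower number from compound 2 to compound 4 (1.62 log units; beyond the scatter), whereas chloro in place of methyl brought only a 1.6-fold lower number from compound 2 to compound 3 (0.21 log units; within the scatter). The methoxy group counts too: with methoxycarbonyl already on the ring, methoxy in place of hydrogen brings a 16-fold lower number from compound 1 to compound 4 (1.19 log units; beyond the scatter), so among these compounds only compound 4 carries both groups, and only compound 4 stands beyond the scatter of all the others.

On these data alone, it remains open whether the methoxycarbonyl group itself is needed at this carbon, or whether a carboxylic acid, an amide or a nitrile there would serve as well. As far as these compounds go, it is equally open whether an ethoxy group could take the place of the methoxy group. Nothing measured here explains why this combination does so much better.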